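Nitro for Chlorine: Expected Cytotoxicity of Compound 4

The compounds below may be only part of what the source reports. "The series", "measured", "known", "first", "only" and "open" are said of these compounds alone.

Compound 1 `O=c1ccoc2cc(OCc3cn(Cc4cccc(Cl)c4)nn3)ccc12`: > 100000 nM
Compound 2 `O=c1ccoc2cc(OCc3cn(Cc4ccc(Br)cc4)nn3)ccc12`: > 100000 nM
Compound 3 `O=c1ccoc2cc(OCc3cn(Cc4ccccc4Cl)nn3)ccc12`: 15100 nM

In a functional assay on MDA-MB-231 cells (Homo sapiens) for cytotoxicity, read by MTT assay, with a stated time of 48 h (on this read-out lower numbers stand for stronger inhibition and higher numbers for weaker inhibition), compound 1 reaches only a limit of the assay, not a number. Compound 2 likewise stops at a limit in this assay. Compound 3 therefore holds the only real number shown, and the steps of an at least 6.6-fold lower number from compound 1 to compound 3 (0.82 log units; beyond the scatter) and an at least 6.6-fold lower number from compound 2 to compound 3 (0.82 log units; beyond the scatter) both favour it.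

Compound 4 `O=c1ccoc2cc(OCc3cn(Cc4ccc([N+](=O)[O-])cc4)nn3)ccc12` is not yet measured. It differs from compound 3 in this way: 4-nitrophenyl in place of 2-chlorophenyl on a saturated chain carbon bound to an aromatic nitrogen. Both measured steps moved away from a 4-substituted phenyl and gave lower numbers, so the reverse direction is expected to raise the number; a step of a 5.3-fold higher number from compound 3 to compound 4 (0.72 log units; beyond the scatter) is estimated. Compound 4 is thus expected at 80000 nM in this assay, within 20000 nM to 300000 nM.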

Compound 4, half-maximal inhibitory concentration: 71300 nM
Compound 4: the middle estimate sits 1.1-fold (0.05 log units) above what was measured; measured number inside the range.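

With 4-nitrophenyl on the saturated chain carbon bound to an aromatic nitrogen, a real number returns in this assay, yet 2-chlorophenyl stays ahead, with a 4.7-fold higher number from compound 3 to compound 4 (0.67 log units; beyond the scatter). Against the two compounds held at a limit, only floors can be read, an at least 1.4-fold lower number from compound 2 to compound 4 (0.14 log units; that floor lies within the scatter) and an at least 1.4-fold lower number from compound 1 to compound 4 (0.14 log units; that floor lies within the scatter), so nitro cannot be ranked against bromo, nor 4-nitrophenyl against 3-chlorophenyl: the limit of > 100000 nM in this assay, at which 2 of the 4 values shown sit.

The compounds shown leave open what an amine or a carboxylic acid in place of the nitro would give. They also leave open whether a longer chain at this carbon would keep the number of compound 3.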